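From pentyl to phenyl: what number comes next?

The source may hold more compounds than are shown below. What is called first, only, known or untested is meant among the compounds shown, and "the series" means these compounds.

Of the compounds shown here, two with a shared core have been measured so far in a physicochemical assay for lipophilicity, measured as octanol-water partition; on this read-out higher numbers stand for higher lipophilicity and lower numbers for lower lipophilicity. Compound 1 `CCCc1cn(C/C=C(\C)CCC=C(C)C)nn1` gives 4.5, while compound 2 `CCCCCc1cn(C/C=C(\C)CCC=C(C)C)nn1` gives 5.45, the higher of the two numbers. Next comes compound 3 `CC(C)=CCC/C(C)=C/Cn1cc(-c2ccccc2)nn1`, which has not yet been measured. Its difference from compound 2 is phenyl in place of pentyl on an aromatic carbon, or in words, phenyl in place of pentyl on an aromatic carbon.

Within the data shown here, only one measured step bears on this change: a number 0.95 log units higher from compound 1 to compound 2 (beyond the scatter), where ethyl takes the place of hydrogen on a saturated chain carbon. That step extends a chain, whereas the new change removes the whole pentyl chain and puts phenyl in its place, so it is only a rough guide. Among the measured compounds shown here, no measured compound here carries phenyl. Going by the modest size of that single step, a modest fall in this assay seems the likeliest outcome, and the expected step is a number 0.55 log units lower from compound 2 to compound 3 (beyond the scatter). For compound 3 the estimated value is 4.9, with an expected range from 4.3 to 5.5.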

Compound 3, partition coefficient: 4.91
Estimate against measurement, compound 3: 0.01 log units below; low and high end bracket the measured number.
By their numbers in this assay, from the lowest: compound 1; then compound 3; then compound 2.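

This position on the aromatic carbon now has a ring to compare with the chains, and in this assay phenyl in place of pentyl gives a number 0.54 log units lower from compound 2 to compound 3 (beyond the scatter) while phenyl in place of propyl gives a number 0.41 log units higher from compound 1 to compound 3 (beyond the scatter) as its second result. The phenyl compound therefore sits between the two chain compounds, and size counted in atoms does not set the order here: phenyl has 6 heavy atoms against 5 for pentyl, yet compound 3 stands lower than compound 2. Nothing available here explains why the ring lands at this point between the two chains.

Going by these compounds, what remains open is how a longer chain, such as octyl, or a benzyl group would compare at this position, and whether an amine or a carboxylic acid would take the number far outside the range these three compounds span. It is also open whether a phenyl ring carrying a chlorine or a methoxy group would stay close to compound 3, since only the unsubstituted ring appears among these compounds.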